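The compounds below may be only part of what the source reports. "The series", "measured", "known", "first", "only" and "open" are said of these compounds alone.

Compound 1 `Cc1nc(S(C)(=O)=O)ccc1Oc1ncnc(OC2CCN(C(=O)SC(C)C)CC2)c1F`: 81%
Compound 2 `Cc1nc(S(C)(=O)=O)ccc1Oc1ncnc(OC2CCN(C(=O)C(C)(F)F)CC2)c1F`: 87%
Compound 3 `Cc1nc(S(C)(=O)=O)ccc1Oc1ncnc(OC2CCN(C(=O)C(C)(C)F)CC2)c1F`: 74%

All three compounds were tested in a functional assay on isolated protein for inhibition of Glucose-dependent insulinotropic receptor (Rattus norvegicus), read by HTRF and cAMP accumulation; on this read-out higher numbers stand for larger maximal responses and lower numbers for smaller maximal responses. They share one core and differ only in the group attached to a carbonyl carbon whose other neighbour is an amide-type nitrogen in a ring. Compound 1, which carries an isopropylsulfanyl group there, sits between the other two in this assay: a number 6 percentage points higher from compound 1 to compound 2 (within the scatter) and a number 7 percentage points lower from compound 1 to compound 3 (within the scatter). Among the measured compounds shown here, the only step that goes beyond the scatter lies between the other two: a number 13 percentage points lower from compound 2 to compound 3 (beyond the scatter).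

Compound 4 `Cc1nc(S(C)(=O)=O)ccc1Oc1ncnc(OC2CCN(C(=O)c3nc(C(C)(C)F)no3)CC2)c1F` has not yet been measured in this assay. Compared with compound 1 the change is a group of 9 heavy atoms (5 carbon, 2 nitrogen, 1 oxygen, 1 fluorine; one five-membered aromatic ring with 3 hetero atoms) in place of a group of 4 heavy atoms (3 carbon, 1 sulfur; no ring), on a carbonyl carbon. For the measured compounds named here, both measured exchanges at this carbonyl carbon stayed within the scatter, yet each of them swapped the isopropylsulfanyl group for a small fluorinated chain, not for an aromatic ring; no measured step covers a group of the kind entering compound 4. With only these small steps to go on, the expectation is for no step beyond the scatter: a number 1 percentage points lower from compound 1 to compound 4 (within the scatter) is estimated. Compound 4 is therefore expected to give 80%, with a range from 65% to 92%.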

Compound 4, largest response reached (reported as efficacy), in percent of the reference or control that the assay uses: 84%
Compound 4: middle estimate off by 4 percentage points, on the low side, and the stated range covers the measured number.
By their numbers in this assay, from the lowest: compounds 3, 1, 4 and 2 (each within the scatter of the next, the first and the last beyond it).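

In this assay, putting a much larger group on the carbonyl carbon, one that holds a five-membered aromatic ring with 3 hetero atoms, leaves the maximal response within the scatter of the isopropylsulfanyl group (a number 3 percentage points higher from compound 1 to compound 4 (within the scatter)). The same is true against the two small fluorinated chains (a number 10 percentage points higher from compound 3 to compound 4 (within the scatter); a number 3 percentage points lower from compound 2 to compound 4 (within the scatter)), so this position accepts a ring-bearing group of 9 heavy atoms as well as groups of 4 heavy atoms, and the new group cannot be told apart from any of the three smaller ones on this read-out. No measured data here explain this result.

The compounds shown leave open whether other kinds of group on the carbonyl carbon, such as a plain phenyl ring, an amine or a carboxylic acid, would keep the response in this range. Maximal response alone also says nothing about the concentration needed to reach it, so two compounds with matching numbers here could still differ in that respect.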